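The compounds below may be only part of what the source reports. "The series", "measured", "known", "first", "only" and "open" are said of these compounds alone.

Measured so far:
Compound 1 `COc1ccc(/C=N/NC(=O)Nc2ccc(Oc3ccnc(-c4nncn4CCN(C)C)c3)c(F)c2)c(OC)c1OC` — in a functional assay on HT-29 cells (Homo sapiens) for cytotoxicity, read by MTT assay, with a stated time of 72 h (a higher number here means a weaker inhibitor, a lower number a stronger inhibitor), compound 1 gives 3970 nM.
Compound 2 `CN(C)CCn1cnnc1-c1cc(Oc2ccc(NC(=O)N/N=C/c3ccc(F)cc3F)cc2F)ccn1` — in this assay compound 2 gives 960 nM.

Compound 2 has the lower of the two numbers shown, and the only step known here runs a 4.1-fold lower number from compound 1 to compound 2 (0.62 log units; beyond the scatter). Compound 3 `CN(C)CCn1cnnc1-c1cc(Oc2ccc(NC(=O)N/N=C/c3ccc(O)cc3)cc2F)ccn1` has not yet been measured. It keeps the whole core of compound 2 and differs at one place only: 4-hydroxyphenyl in place of 2,4-difluorophenyl on a carbon with a double bond to nitrogen. For the measured compounds named here, no measured step exchanges a phenyl group for a 4-hydroxyphenyl group, so the size of the step from compound 1 to compound 2 tells how much one change at this position can move the number, but not which way this one will go. On that basis compound 3 is expected to give a number near that of compound 2, most likely a little higher, as a step of a 1.9-fold higher number from compound 2 to compound 3 (0.27 log units; within the scatter), which need not exceed the scatter. The estimate for compound 3 is 1800 nM, with a range from 600 nM to 5500 nM.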

Compound 3, half-maximal inhibitory concentration: 1920 nM
For compound 3 the middle estimate is 1.1-fold (0.03 log units) below the measured one, within the range that was stated.
By their numbers in this assay, from the lowest: compounds 2 and 3 (each within the scatter of the next); then compound 1.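

In this assay, 4-hydroxyphenyl in place of 2,4-difluorophenyl gives a 2.0-fold higher number from compound 2 to compound 3 (0.30 log units; within the scatter), so these two groups cannot be told apart here, even though only 4-hydroxyphenyl carries a hydrogen-bond donor and acceptor. Against the third group, 4-hydroxyphenyl in place of 2,3,4-trimethoxyphenyl gives a 2.1-fold lower number from compound 1 to compound 3 (0.32 log units; beyond the scatter), a modest step, so among these three compounds the lower number is not tied to fluorine: a group without it, in compound 3, also stands apart from compound 1. No measurement is available here to explain why these groups compare as they do.

On these data alone, it remains open where a plain phenyl ring with no substituent would fall at this position. A phenyl ring carrying an amine or a carboxylic acid in place of the hydroxyl also remains to be placed against compounds 1, 2 and 3.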